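A few compounds are considered here, and "the series" means these few. Any claim that something is new, unique, unknown or untested is made for them only; others in the source may bear on it.

Measured in a physicochemical assay, with a stated time of 30 min; a higher number here means a weaker inhibitor, a lower number a stronger inhibitor:
compound 1 (`CC(C)=N/N=C1\SCC(=O)N1Cc1ccc(N)cc1`) gives 2040000 nM
compound 2 (`C/C(=N\N=C1/SCC(=O)N1Cc1ccccc1F)c1cccs1`) gives 15700000 nM
compound 3 (`O=C1CS/C(=N\N=C2CCCC2)N1Cc1ccccc1F`) gives 12400000 nM

Compound 3 lies within the scatter of compound 2, while compound 1 gives a lower number, beyond the scatter. Compound 4 (`O=C1CS/C(=N\N=C2CCCC2)N1Cc1ccc(Cl)cc1`) is not yet measured and differs from compound 3 in one place: 4-chlorophenyl in place of 2-fluorophenyl on a saturated chain carbon bound to an amide-type nitrogen in a ring. For the measured compounds named here, no single-change step has been measured. In this assay a small move toward a lower number is expected, with nothing beyond the scatter. The expected step is a 1.4-fold lower number from compound 3 to compound 4 (0.14 log units; within the scatter) by estimate. For compound 4 the estimated value is 9000000 nM with an expected range from 3000000 nM to 20000000 nM in these notes.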

Compound 4, half-maximal inhibitory concentration: 18300000 nM
Estimate against measurement, compound 4: 2.0-fold (0.31 log units) below, within the range that was stated.
By their numbers in this assay, from the lowest: compound 1; then compounds 3, 2 and 4 (each within the scatter of the next).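

In this assay, for the compounds shown here, the first single-change step, 4-chlorophenyl in place of 2-fluorophenyl on a saturated chain carbon bound to an amide-type nitrogen in a ring, is a 1.5-fold higher number from compound 3 to compound 4 (0.17 log units; within the scatter) and stays within the scatter. At this position, the exchange of these two groups therefore gives no resolved change in the read-out. Nothing measured here speaks to the reason for this result.

From the compounds shown here alone, whether a carboxylic acid or a longer chain at this place would move the number beyond the scatter remains open. Compound 1 differs from compound 3 in more than one place, and its lower number cannot be assigned to any single group.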